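A few compounds are considered here, and "the series" means these few. Any claim that something is new, unique, unknown or untested is made for them only; others in the source may bear on it.

Compounds measured in an assay on isolated protein for inhibition of Polyunsaturated fatty acid 5-lipoxygenase (Homo sapiens); a higher number here means a weaker inhibitor, a lower number a stronger inhibitor:
compound 1, `Cc1cccc(N2CCCC(=O)N2)c1`, 3400 nM
compound 2, `O=C1CCCN(c2cccc(Cl)c2)N1`, 2500 nM
compound 3, `CC(C)(C)C(=O)c1cccc(N2CCCC(=O)N2)c1`, 15000 nM

Compound 3 stands highest of the three numbers in this assay; the steps up to it were a 4.4-fold higher number from compound 1 to compound 3 (0.64 log units; beyond the scatter) and a 6.0-fold higher number from compound 2 to compound 3 (0.78 log units; beyond the scatter), both beyond the scatter. The small halogen-for-methyl exchange, a 1.4-fold lower number from compound 1 to compound 2 (0.13 log units; within the scatter), stayed within the scatter.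

Compound 4, `O=C1CCCN(c2cccc(F)c2)N1`, has not yet been measured. It differs from compound 3 by fluoro in place of (tert-butyl)carbonyl on an aromatic carbon. Both steps into compound 3 bear on this change, since each added the same (tert-butyl)carbonyl group and each raised the number; removing it for a small halogen is therefore expected to lower the number by roughly that amount, a step of about a 5.4-fold lower number from compound 3 to compound 4 (0.73 log units; beyond the scatter). Compound 4 is estimated at 2800 nM, with a range from 1200 nM to 6500 nM.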

Compound 4, half-maximal inhibitory concentration: 5500 nM
The estimate for compound 4 lay 2.0-fold (0.29 log units) below the measured number; measured number inside the range.
By their numbers in this assay, from the lowest: compounds 2, 1 and 4 (each within the scatter of the next, the first and the last beyond it); then compound 3.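

In this assay, among the compounds shown here, fluoro in place of (tert-butyl)carbonyl on this aromatic carbon gave a smaller change than the earlier steps at this position (a 2.7-fold lower number from compound 3 to compound 4 (0.44 log units; beyond the scatter)). The two halogens also proved not to be interchangeable here, with fluoro in place of chloro giving a step beyond the scatter (a 2.2-fold higher number from compound 2 to compound 4 (0.34 log units; beyond the scatter)), while fluoro in place of methyl stayed within it (a 1.6-fold higher number from compound 1 to compound 4 (0.21 log units; within the scatter)). Nothing available accounts for these differences. As far as these compounds go, how a methoxy group, an amine or a carboxylic acid on this carbon would read remains open, as does the effect of the same groups elsewhere on the aromatic ring.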